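Trifluoromethyl to Methyl on the Fused Ring of Compound 1

This account rests on a few compounds, and the source may have more. Where it says the series, first, only, none or still open, it means among the compounds named here.

Of the compounds shown here, three sharing one core have been measured in an assay on L cells for inhibition of Protein-serine O-palmitoleoyltransferase porcupine (Mus musculus), read by reporter gene assay, with a stated time of 24 h; a lower number here means that less compound is needed, a higher number that more compound is needed for the effect. Compound 1 `COc1ccccc1-n1c(SCC(=O)Nc2nc3ccc(C(F)(F)F)cc3s2)nc2c(c1=O)SCC2` gives 30 nM, the low end of the three numbers. Compound 2 `O=C(CSc1nc2c(c(=O)n1-c1ccccc1)SCC2)Nc1nc2ccc(C(F)(F)F)cc2s1` gives 40 nM, and the step of a 1.3-fold higher number from compound 1 to compound 2 (0.12 log units; within the scatter) is within the scatter, so the two cannot be ranked. Compound 3 `O=C(CSc1nc2c(c(=O)n1-c1ccc(F)cc1)SCC2)Nc1nc2ccc(C(F)(F)F)cc2s1` gives 100 nM, with a 3.3-fold higher number from compound 1 to compound 3 (0.52 log units; beyond the scatter) and a 2.5-fold higher number from compound 2 to compound 3 (0.40 log units; beyond the scatter) both beyond the scatter; compound 1 is thus separated only from compound 3.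

Compound 4 `COc1ccccc1-n1c(SCC(=O)Nc2nc3ccc(C)cc3s2)nc2c(c1=O)SCC2` differs from compound 1 in one place: methyl in place of trifluoromethyl on an aromatic carbon. Going by the values given here, none of the measured steps touches this place; all three concern the aryl group on the aromatic nitrogen of the core, and the largest of them, a 3.3-fold higher number from compound 1 to compound 3 (0.52 log units; beyond the scatter), is modest. Among the compounds with values here, there is no direct precedent for the exchange on the fused ring, and the expectation rests only on the observation that single changes on this core have so far moved this assay by modest amounts at most. Compound 4 is expected to show a step of a 2.0-fold higher number from compound 1 to compound 4 (0.30 log units; within the scatter), a modest rise in the number or none beyond the scatter. The estimate for compound 4 in this assay is 60 nM, with a range from 20 nM to 180 nM.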

Compound 4, half-maximal effective concentration: 25 nM
Estimate against measurement, compound 4: 2.4-fold (0.38 log units) above; the measured number falls inside the stated range.
By their numbers in this assay, from the lowest: compounds 4, 1 and 2 (each within the scatter of the next); then compound 3.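

Going by these compounds alone, the three earlier steps all concern the aryl group on the aromatic nitrogen of the core, so compound 4 gives the first reading at the other end of the molecule, on an aromatic carbon of the six-membered aromatic ring of carbon only within the fused system. In this assay, methyl in place of trifluoromethyl gives a 1.2-fold lower number from compound 1 to compound 4 (0.08 log units; within the scatter), so with the 2-methoxyphenyl group on the nitrogen, the trifluoromethyl group is not needed to keep the number in this range: the substituent goes from four heavy atoms to one, and the two compounds cannot be ranked. No measurement is available that would explain why this exchange leaves the reading within the scatter.

The compounds shown leave open whether this position accepts groups of another kind, such as an amine, a carboxylic acid or a longer alkyl chain, or simply hydrogen in place of methyl. They also leave open whether the same exchange would read alike with the phenyl group of compound 2 or the 4-fluorophenyl group of compound 3 on the nitrogen.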